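Notes on the step to compound 4

This account rests on a few compounds, and the source may have more. Where it says the series, first, only, none or still open, it means among the compounds named here.

In an ADME assay on Vero cells (Chlorocebus sabaeus) for cytotoxicity, read by MTT assay, with a stated time of 96 h (a higher number here means that more compound is tolerated, a lower number that less compound is tolerated), compound 2 `C/C(=N\NC(N)=O)c1ccc2c(c1)nc(-c1ccc(Cl)cc1)n2C1CCCCC1` reads > 100000 nM, which is a limit and not a number. Compound 3 `C/C(=N\NC(N)=O)c1ccc2c(c1)nc(-c1ccc(C(F)(F)F)cc1)n2C1CCCCC1` reads > 100000 nM, which is also a limit. Compound 3 therefore has no exact value and stands at the limit of > 100000 nM in this assay, at which 2 of the 3 values shown sit.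

The change to compound 4 `COc1ccc(-c2nc3cc(/C(C)=N/NC(N)=O)ccc3n2C2CCCCC2)c(OC)c1` is on an aromatic carbon between two ring nitrogen atoms: 2,4-dimethoxyphenyl in place of 4-(trifluoromethyl)phenyl on an aromatic carbon.

For the measured compounds named here, the one measured step that bears on this, a step that the two limits leave unreadable from compound 2 to compound 3, offers no size to carry over. Going by the values given here, the only exact number in this assay comes from compound 1 `COc1ccc(-c2nc3cc(C(C)=O)ccc3n2C2CCCCC2)c(OC)c1`, which also bears 2,4-dimethoxyphenyl and gives 70000 nM. With no readable step to draw on, no shift beyond the scatter is expected in this assay, and another limit reading is likely. The expected change is a number no higher from compound 3 to compound 4 (the limit leaves the size open), and it is only an estimate resting on a single exact value. For compound 4 the estimated value is 100000 nM, with an expected range from 50000 nM to 200000 nM.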

Compound 4, half-maximal cytotoxic concentration: 20000 nM
The estimate for compound 4 lay 5.0-fold (0.70 log units) above the measured number, outside the stated range (below it).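

In this assay, the group on the aromatic carbon between two ring nitrogen atoms now has a readable consequence: 2,4-dimethoxyphenyl gives an at least 5.0-fold lower number from compound 3 to compound 4 (0.69 log units; beyond the scatter) and an at least 5.0-fold lower number from compound 2 to compound 4 (0.69 log units; beyond the scatter). For the compounds shown here, the earlier compounds showed no such step, as the only comparison among them ended in two limits. With 2,4-dimethoxyphenyl held constant, the other change also counts, since the group of 7 heavy atoms in place of the group of 3 heavy atoms gives a 3.5-fold lower number from compound 1 to compound 4 (0.54 log units; beyond the scatter).

From the compounds shown here alone, compound 2 and compound 3 carry limits, so the full size of the steps from them stays open: the limit of > 100000 nM in this assay, at which 2 of the 4 values shown sit. Also open is whether a single methoxy group, as in 4-methoxyphenyl, or an amine on that phenyl ring would give the same lower number.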